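Removing the Side Chain from Compound 1

The source may hold more compounds than are shown below. What is called first, only, known or untested is meant among the compounds shown, and "the series" means these compounds.

Measured compounds and their values:
compound 1 `N=C(N)NCCC[C@H](NC(=O)CN(c1nc(Cl)nc2[nH]cnc12)C1CC1)C(=O)O`: 7.19%
compound 2 `CC(C)[C@H](NC(=O)CN(c1nc(Cl)nc2[nH]cnc12)C1CC1)C(=O)OCc1ccccc1`: 17.9%
compound 3 `NCCCC[C@H](NC(=O)CN(c1nc(Cl)nc2[nH]cnc12)C1CC1)C(=O)OCc1ccccc1`: 9.88%

All three compounds share one core and differ only in the group on a saturated chain carbon bound to an amide-type nitrogen and a carbonyl carbon. In a functional assay on the whole organism (Tail, strain ICR) with Mus musculus as the target, in the tail flick test, with a stated time of 150 min, at a dose of 25 umol/kg by the oral route (a higher number here means a stronger effect of the compound at the dose given, a lower number a weaker effect), compound 1 gives the lowest of the three numbers. Compound 3 stands nearest to it, and the gap between them is within the scatter, so no order can be read from those two. Compound 2 stands furthest away, higher than compound 1 by more than the scatter.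

Compound 4 `O=C(O)CNC(=O)CN(c1nc(Cl)nc2[nH]cnc12)C1CC1` has not yet been measured in this assay. It differs from compound 1 by a hydrogen atom in place of a group of 7 heavy atoms (4 carbon, 3 nitrogen; no ring), on a saturated chain carbon bound to an amide-type nitrogen and a carbonyl carbon. Among the measured compounds shown here, one measured step bears on this place: a number 8 percentage points lower from compound 2 to compound 3 (within the scatter). That exchange of one side chain for another left the read-out within the scatter. For the measured compounds named here, no measured step removes the side chain altogether, so the guidance is thin, but what exists points to a small step. For compound 4 the expected change is a number 1.8 percentage points higher from compound 1 to compound 4 (within the scatter). Compound 4 is therefore estimated at 9%, with a range from 0% to 22%.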

Compound 4, a percentage reported as activity, at one dose (the size of the read-out at that dose, not a potency): 9.08%
For compound 4 the middle estimate is 0.1 percentage points below the measured one, within the range that was stated.
By their numbers in this assay, from the lowest: compounds 1, 4, 3 and 2 (each within the scatter of the next, the first and the last beyond it).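

Among the compounds shown here, putting a hydrogen atom in place of the group of 7 heavy atoms in this assay gives a number 1.9 percentage points higher from compound 1 to compound 4 (within the scatter), and this is the first measured step that takes the side chain away altogether instead of exchanging it for another one. It also concerns a different pair: compound 1 and compound 4 both end in a free carboxylic acid, while the earlier step at this saturated chain carbon, bound to an amide-type nitrogen and a carbonyl carbon, links two benzyl esters, so the side chain can now be removed from a free acid with no change that stands clear of the scatter at this single dose. Nothing measured alongside these read-outs speaks to what lies behind this result.

The compounds shown leave open whether a small group such as methyl, or a phenyl ring on a short chain, would give a different read-out at this place on the free acid. For the compounds shown here, they also leave open what a hydrogen atom at this place would give in a benzyl ester, where the only comparison so far is between an isopropyl and a 4-aminobutyl side chain.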